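From Pyridin-3-yl to 4-Cyanophenyl on the Ring Amine

The compounds below may be only part of what the source reports. "The series", "measured", "known", "first", "only" and "open" are said of these compounds alone.

Of the compounds shown here, three built on one shared core have been measured in a functional assay on A-375 cells (Homo sapiens) for antiproliferative activity, read by CCK-8 assay, with a stated time of 72 h, tested at 2 uM; a lower number here means a weaker effect, a higher number a stronger effect of the compound at the concentration tested. Compound 1 `Nc1ccccc1NC(=O)c1ccc(CSC(=S)N2CCN(c3ccc(Cl)cc3)CC2)cc1` gives 32.2%, compound 2 `Nc1ccccc1NC(=O)c1ccc(CSC(=S)N2CCN(c3cccnc3)CC2)cc1` gives 40.5%, and compound 3 `Nc1ccccc1NC(=O)c1ccc(CSC(=S)N2CCc3cc(Cl)ccc32)cc1` gives 31.9%. Compound 2 holds the highest of these three numbers, yet its gaps to compound 1 and to compound 3 both fall within the scatter, so no ordering among the three can be claimed. For the measured compounds named here, the single one-place step measured so far, a number 8.3 percentage points higher from compound 1 to compound 2 (within the scatter), put pyridin-3-yl in place of 4-chlorophenyl on an amine nitrogen in a ring and stayed within the scatter.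

Compound 4 `N#Cc1ccc(N2CCN(C(=S)SCc3ccc(C(=O)Nc4ccccc4N)cc3)CC2)cc1` has not yet been measured. It differs from compound 2 at that same place: 4-cyanophenyl in place of pyridin-3-yl on an amine nitrogen in a ring. Going by the values given here, only one measured step bears on this position, and because a number 8.3 percentage points higher from compound 1 to compound 2 (within the scatter) remained within the scatter, the expected change in this assay is small, with no firm direction beyond the scatter. Compound 4 is estimated to give 36% in this assay, within a range of 24% to 48%. This estimate means an expected step of a number 4.5 percentage points lower from compound 2 to compound 4 (within the scatter).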

Compound 4, a percentage reported as inhibition, at one concentration (the size of the read-out at that concentration, not a potency): 41.4%
Compound 4: the middle estimate sits 5.4 percentage points below what was measured; the measured number falls inside the stated range.
By their numbers in this assay, from the lowest: compounds 3, 1, 2 and 4 (each within the scatter of the next).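

In this assay, 4-cyanophenyl in place of pyridin-3-yl on the amine nitrogen in a ring gave a number 0.9 percentage points higher from compound 2 to compound 4 (within the scatter), so a carbon-only aromatic ring bearing a nitrile could not be told apart from the ring with a hetero atom. For the compounds shown here, the same compound also gave the first comparison of two groups on the same phenyl ring, cyano in place of chloro on an aromatic carbon, with a number 9.2 percentage points higher from compound 1 to compound 4 (within the scatter), which leaves all three steps among compounds 1, 2 and 4 within the scatter. No measurement offered here explains these steps.

From the compounds shown here alone, whether any group at this position can move the number beyond the scatter stays open, for instance a carboxylic acid or an amine on the phenyl ring, or a longer chain in place of the aromatic ring. A read-out at one concentration also leaves the potency of these compounds open.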